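From 4-bromophenyl to 4-methylphenyl in the series

This account rests on a few compounds, and the source may have more. Where it says the series, first, only, none or still open, it means among the compounds named here.

In a functional assay on HeLa cells (Homo sapiens) for inhibition, read by CCK-8 assay, with a stated time of 48 h (on this read-out lower numbers stand for stronger inhibition and higher numbers for weaker inhibition), compound 3 `O=C1CSC(N2N=C(c3ccc(Br)cc3)CC2c2cccc3ccccc23)=N1` gives 5810 nM and lies within the scatter of both other measured compounds. Compound 1 `O=C1CSC(N2N=C(c3ccc(F)cc3)CC2c2cccc3ccccc23)=N1` gives 11300 nM on the same read-out, and compound 2 `Cc1ccc(C2=NN(C3=NC(c4ccccc4)CS3)C(c3cccc4ccccc34)C2)cc1` gives 4290 nM there.

Compound 4 `Cc1ccc(C2=NN(C3=NC(=O)CS3)C(c3cccc4ccccc34)C2)cc1` keeps the rest of compound 3 and carries methyl in place of bromo on an aromatic carbon para to a large group. Among the measured compounds shown here, only one measured step bears directly on this place. Bromo in place of fluoro gave a 1.9-fold lower number from compound 1 to compound 3 (0.29 log units; within the scatter) and so stayed within the scatter. For the measured compounds named here, compound 2 also carries 4-methylphenyl, but its core differs, so it offers only a loose guide and no clean step.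

With that single small step as precedent, no change beyond the scatter is expected in this assay. The estimate means a 1.0-fold higher number from compound 3 to compound 4 (0.01 log units; within the scatter) and is expected to fall within the scatter. For compound 4 the estimated value is 6000 nM with an expected range from 2800 nM to 13000 nM in this series.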

Compound 4, half-maximal inhibitory concentration: 3210 nM
For compound 4 the middle estimate is 1.9-fold (0.27 log units) above the measured one; the measured number falls inside the stated range.
By their numbers in this assay, from the lowest: compounds 4, 2, 3 and 1 (each within the scatter of the next, the first and the last beyond it).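

Methyl in place of bromo at this position gives a 1.8-fold lower number from compound 3 to compound 4 (0.26 log units; within the scatter) in this assay and so leaves 4-methylphenyl and 4-bromophenyl unseparated on this read-out. Methyl in place of fluoro gives a 3.5-fold lower number from compound 1 to compound 4 (0.55 log units; beyond the scatter) and is the first step at this position to clear the scatter, though it remains modest and both of the steps linking these compounds through compound 3 stay within the scatter. With 4-methylphenyl held constant, the exchange of the group on the amine nitrogen in a ring gives a 1.3-fold lower number from compound 2 to compound 4 (0.13 log units; within the scatter) and does not separate the two groups there.

No measurement is available to explain these steps. Going by these compounds, whether an amine, a carboxylic acid or a longer chain at this position would move the number beyond the scatter from that of compound 4 remains open.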